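Swapping One Halogen for Another on the Shared Core

The source may hold more compounds than are shown below. What is called first, only, known or untested is meant among the compounds shown, and "the series" means these compounds.

Within the data shown here, compound 2 `Oc1c(Cl)cc(Cl)cc1-c1nc2cc(F)ccc2[nH]1` gives 2870 nM in an assay for inhibition of Alpha amylase (Homo sapiens), with a stated time of 10 min (a higher number here means a weaker inhibitor, a lower number a stronger inhibitor), the higher of the two numbers so far, yet compound 1 `Oc1c(Br)cc(Cl)cc1-c1nc2ccccc2[nH]1` with 2850 nM in this assay lies within the scatter of it, so the two cannot be told apart. Compound 3 `Oc1c(Br)cc(Cl)cc1-c1nc2cc(F)ccc2[nH]1` differs from compound 2 by bromo in place of chloro on an aromatic carbon. Among the measured compounds shown here, no measured pair shows this change alone. Because compound 1, which also carries bromo rather than chloro, gives 2850 nM, no step beyond the scatter is expected. Compound 3 is estimated at 2800 nM, range 1400 nM to 5600 nM, an expected step of a 1.0-fold lower number from compound 2 to compound 3 (0.01 log units; within the scatter).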

Compound 3, half-maximal inhibitory concentration: 2860 nM
Compound 3: middle estimate off by 1.0-fold (0.01 log units), on the low side, and the stated range covers the measured number.
By their numbers in this assay, from the lowest: compounds 1, 3 and 2 (each within the scatter of the next).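

In this assay, bromo in place of chloro on the aromatic carbon ortho to the hydroxy group now has a measured pair, giving a 1.0-fold lower number from compound 2 to compound 3 (0.00 log units; within the scatter), so these two halogens cannot be told apart at this position. Fluoro in place of hydrogen on an aromatic carbon, with bromo present, gives a 1.0-fold higher number from compound 1 to compound 3 (0.00 log units; within the scatter), so that change cannot be told apart from no change either. No supporting data bear on why these numbers stay so close. The compounds shown leave open what a non-halogen group at the bromo position, such as an amine or a carboxylic acid, would do to the number.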